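This account rests on a few compounds, and the source may have more. Where it says the series, first, only, none or still open, it means among the compounds named here.

Measured compounds: compound 1 `CCc1ccc2[nH]c(=O)c(CN(Cc3ccc(OCOC)cc3)Cc3ccc(C(C)(C)C)cc3)cc2c1`, compound 2 `Cc1ccc2[nH]c(=O)c(CN(Cc3ccc(O)cc3)Cc3ccc(C(C)(C)C)cc3)cc2c1`, compound 3 `COc1ccc(CN(Cc2ccc(C(C)(C)C)cc2)Cc2cc3cc(C)ccc3[nH]c2=O)cc1`.

In a toxicity assay on MDCK cells (Canis lupus familiaris) for cytotoxicity, read by crystal violet staining, with a stated time of 48 h (on this read-out lower numbers stand for higher toxicity in this test and higher numbers for lower toxicity in this test), compound 1 returns only a limit of the assay, > 10000 nM. In this assay compound 2 gives 4900 nM. In this assay compound 3 also returns only a limit, > 10000 nM, so its standing is known as a floor rather than a number. Going by the values given here, the one measured step that bears on the change is an at least 2.0-fold higher number from compound 2 to compound 3 (0.30 log units; that floor lies within the scatter). Compound 4 `Cc1ccc2[nH]c(=O)c(CN(Cc3ccc(OCCO)cc3)Cc3ccc(C(C)(C)C)cc3)cc2c1` differs from compound 3 by hydroxymethyl in place of hydrogen on a saturated chain carbon bound to an oxygen on an aromatic ring. Since that measured step runs into (the limit of > 10000 nM in this assay, at which 2 of the 3 values shown sit), no step beyond the scatter is expected in this assay, and a limit is again the likely outcome. The estimate for compound 4 is 10000 nM, with a range from 4000 nM to 30000 nM. This estimate means a step of a number no higher from compound 3 to compound 4 (the limit leaves the size open).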

Compound 4, half-maximal cytotoxic concentration: > 5000 nM
Compound 4: only a limit was reported (the forecaster's own chance of this, stated with the estimate: 60%); the middle value is on the limit's open side.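

In this assay compound 4 also returns only a limit, > 5000 nM, so a chain ending in a hydroxyl on this oxygen yields no measured number either. Its step reads an at least 1.0-fold higher number from compound 2 to compound 4 (0.00 log units; that floor lies within the scatter), so the limit does not set 2-hydroxyethyl apart from the hydrogen of compound 2. The step between the two limited compounds, compound 3 and compound 4, cannot be read because neither gives a number: the limit of > 5000 nM in this assay, at which 1 of the 4 values shown sits.

As far as these compounds go, how a longer chain, a terminal amine or a carboxylic acid on this oxygen would read remains open. Where compound 4 truly stands also stays unknown.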